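The source may report more compounds than this note shows. Statements on the series, on what has been measured and on what is new or still open speak of the compounds shown alone.

Of the compounds shown here, two that share one core have been measured in an assay on isolated protein for inhibition of tyrosine-protein kinase Mer (Homo sapiens), read by LC-MS; on this read-out higher numbers stand for weaker inhibition and lower numbers for stronger inhibition. Compound 1 `Cc1cc(-c2c(C)nn(C)c2C)ccc1-c1nnc(N(C)Cc2ccc3nccn3c2)o1` gives 3.16 nM in this assay, and compound 2 `Cc1cc(-c2c(C)n[nH]c2C)ccc1-c1nnc(N(C)Cc2ccc3nccn3c2)o1` gives 39.8 nM. Compound 2 therefore stands at the higher of the two numbers, the weaker end. Among the measured compounds shown here, the only measured step is a 13-fold higher number from compound 1 to compound 2 (1.10 log units; beyond the scatter), and it came with hydrogen in place of methyl on an aromatic nitrogen, so removing that methyl cost a lot of inhibition.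

Compound 3 `Cc1cc(-c2c(C#N)nn(C)c2C)ccc1-c1nnc(N(C)Cc2ccc3nccn3c2)o1` has not yet been measured. Its difference from compound 2 is 3-cyano-1,5-dimethyl-1H-pyrazol-4-yl in place of 3,5-dimethyl-1H-pyrazol-4-yl on an aromatic carbon. This change puts the methyl back onto the aromatic nitrogen, as in compound 1, and at the same time exchanges one methyl of the pyrazole for a nitrile. For the measured compounds named here, the step that bears on it is a 13-fold higher number from compound 1 to compound 2 (1.10 log units; beyond the scatter), read in reverse; the nitrile part has no measured counterpart here. A large step towards a lower number is therefore expected, a 10-fold lower number from compound 2 to compound 3 (1.00 log units; beyond the scatter), with wide uncertainty from the nitrile. Compound 3 is estimated at 4 nM, within 1 nM to 20 nM.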

Compound 3, half-maximal inhibitory concentration: 31.6 nM
Compound 3: middle estimate off by 7.9-fold (0.90 log units), on the low side, and the stated range ends below it.
By their numbers in this assay, from the lowest: compound 1; then compounds 3 and 2 (each within the scatter of the next).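

Keeping the methyl on the aromatic nitrogen and exchanging a methyl on an aromatic carbon of the pyrazole for a nitrile gives a 10-fold higher number from compound 1 to compound 3 (1.00 log units; beyond the scatter) in this assay and so shows that this carbon position also matters: a change there costs inhibition even with the nitrogen methyl in place. The full replacement of 3,5-dimethyl-1H-pyrazol-4-yl by 3-cyano-1,5-dimethyl-1H-pyrazol-4-yl gives a 1.3-fold lower number from compound 2 to compound 3 (0.10 log units; within the scatter) and so does not recover the inhibition lost in a 13-fold higher number from compound 1 to compound 2 (1.10 log units; beyond the scatter) on its own; the nitrogen methyl therefore does not bring a low number with any group at that carbon. Compound 1 remains the strongest of the three in this assay, and nothing shown here explains the cost of the nitrile.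

From the compounds shown here alone, how the two changes combine remains open, and a pyrazole carrying the nitrile together with a hydrogen on the aromatic nitrogen would separate them. Going by these compounds, it is also open whether another group on that carbon, such as chlorine, ethyl or a primary amide, would stay nearer to compound 1 than the nitrile does.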